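The compounds below may be only part of what the source reports. "The series", "measured", "known", "first", "only" and "open" are said of these compounds alone.

Measured so far in a functional assay on the whole organism (strain Albino Swiss CD1) with Mus musculus as the target; a higher number here means that more compound is needed for the effect, a lower number that less compound is needed:
- compound 1 `CCC(C(=O)NCc1cccc(Cl)c1)N1C(=O)CCC1=O`: 78.9 mg/kg
- compound 2 `CCC(C(=O)NCc1ccc(Cl)cc1)N1C(=O)CCC1=O`: 50.8 mg/kg

Compound 2 gives the lowest of the two numbers; its nearest neighbour is compound 1, separated by a 1.6-fold lower number from compound 1 to compound 2 (0.19 log units; within the scatter), so the two cannot be told apart on this assay.

Compound 3 `CCC(C(=O)NCc1ccccc1F)N1C(=O)CCC1=O` is not yet measured. It differs from compound 2 by 2-fluorophenyl in place of 4-chlorophenyl on a saturated chain carbon bound to an amide-type nitrogen. Within the data shown here, the only measured step that touches the same place, on a saturated chain carbon bound to an amide-type nitrogen, is a 1.6-fold lower number from compound 1 to compound 2 (0.19 log units; within the scatter), where one chlorophenyl replaced another chlorophenyl and the number stayed within the scatter. Among the measured compounds shown here, no measured pair exchanges chlorine for fluorine, so the change to compound 3 has no direct precedent; what the data show is that reshaping the halogenated ring at that place moved the number little. For compound 3 a step of a 1.2-fold higher number from compound 2 to compound 3 (0.07 log units; within the scatter) is therefore expected, that is, none beyond the scatter, in this assay. For the measured compounds named here, compound 3 is estimated at 60 mg/kg, within a range of 30 mg/kg to 130 mg/kg; the range is kept wide, since only a single measured step serves as a guide.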

Compound 3, dose for half-maximal effect: 65.7 mg/kg
Beside the measured number, compound 3's estimate is 1.1-fold (0.04 log units) below it; the measured number falls inside the stated range.
By their numbers in this assay, from the lowest: compounds 2, 3 and 1 (each within the scatter of the next).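

The earlier pair only exchanged one chlorophenyl for another, whereas compound 3 also changes the halogen itself, and in this assay that exchange stays within the scatter on both listed steps: a 1.3-fold higher number from compound 2 to compound 3 (0.11 log units; within the scatter) and a 1.2-fold lower number from compound 1 to compound 3 (0.08 log units; within the scatter). At this place, on a saturated chain carbon bound to an amide-type nitrogen, 2-fluorophenyl therefore cannot be told apart from either 4-chlorophenyl or 3-chlorophenyl, and the three compounds give no basis for ranking these rings or for assigning an effect to the choice of halogen. No supporting data bear on why the number holds so steady across these three rings.

The compounds shown leave open whether this flat response extends beyond halogenated phenyl rings, for instance to an unsubstituted phenyl, a methoxyphenyl, or a phenyl carrying an amine or a carboxylic acid at the same place. They also leave open whether the same insensitivity would hold with a longer chain elsewhere on the shared core, since all three compounds differ only in the halogenated ring.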